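The source may report more compounds than this note shows. Statements on the series, on what has been measured and on what is new or still open speak of the compounds shown alone.

Compound 1 `O=c1[nH]c2ccc(-n3cc(C[C@H](O)COCCOC[C@@H](O)Cc4ccc(-c5ccccc5)cc4)nn3)cc2s1` gives 9200 nM in a functional assay on HCT-116 cells (Homo sapiens) for inhibition, read by MTT assay, with a stated time of 72 h; a lower number here means a stronger inhibitor of growth, a higher number a weaker inhibitor of growth.
Compound 2 `O[C@H](COCCOC[C@@H](O)Cc1cn(-c2ccc3c(c2)OCCO3)nn1)Cc1ccc(-c2ccccc2)cc1` gives 16500 nM in this assay.
Compound 3 `O[C@H](COCCOC[C@@H](O)Cc1cn(-c2cncc3ccccc23)nn1)Cc1ccc(-c2ccccc2)cc1` gives 17800 nM in this assay.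

Compound 3 holds the highest of the three numbers, yet the steps of a 1.9-fold higher number from compound 1 to compound 3 (0.29 log units; within the scatter) and a 1.1-fold higher number from compound 2 to compound 3 (0.03 log units; within the scatter) both lie within the scatter, as does a 1.8-fold higher number from compound 1 to compound 2 (0.25 log units; within the scatter). Compound 4 `O[C@H](COCCOC[C@@H](O)Cc1cn(-c2ccc3[nH]ccc3c2)nn1)Cc1ccc(-c2ccccc2)cc1` differs from compound 3 by 1H-indol-5-yl in place of isoquinolin-4-yl on an aromatic nitrogen. All three measured steps exchange the group on the same aromatic nitrogen, and none of them moved the number beyond the scatter, so the same is expected here: the step of a 1.2-fold lower number from compound 3 to compound 4 (0.07 log units; within the scatter) is estimated to stay within the scatter. Compound 4 is therefore expected to give about 15000 nM in this assay, with a range from 6000 nM to 40000 nM.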

Compound 4, concentration for 50% growth inhibition: 15500 nM
Compound 4: middle estimate off by 1.0-fold (0.01 log units), on the low side; the measured number falls inside the stated range.
By their numbers in this assay, from the lowest: compounds 1, 4, 2 and 3 (each within the scatter of the next).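

At this aromatic nitrogen, 1H-indol-5-yl brings in a hydrogen-bond donor and a five-membered ring while isoquinolin-4-yl takes away a hydrogen-bond acceptor, yet a 1.1-fold lower number from compound 3 to compound 4 (0.06 log units; within the scatter) stays within the scatter. The other two exchanges, a 1.1-fold lower number from compound 2 to compound 4 (0.03 log units; within the scatter) and a 1.7-fold higher number from compound 1 to compound 4 (0.23 log units; within the scatter), also stay within it, so the four groups cannot be told apart in this assay and the result shows tolerance to this change only. Nothing available explains this flat result. Going by these compounds, whether a simple phenyl ring, an aminoalkyl chain or a carboxylic acid at this nitrogen would move the number beyond the scatter remains open.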